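The compounds below may be only part of what the source reports. "The series", "measured", "known", "first", "only" and "open" are said of these compounds alone.

Values in a functional assay on Hep 3B2 cells (Homo sapiens) for inhibition, read by sulforhodamine B assay, with a stated time of 72 h; a higher number here means a weaker inhibitor, a lower number a stronger inhibitor:
- Compound 1 `C[C@H](Nc1ncnc2[nH]cnc12)c1nn(-c2cccc(F)c2)c2cc(F)ccc12`: > 40000 nM (a limit)
- Compound 2 `C[C@H](Nc1ncnc2[nH]cnc12)c1nn(-c2ccc(C#N)cc2)c2cc(F)ccc12`: 13500 nM
- Compound 3 `C[C@H](Nc1ncnc2[nH]cnc12)c1nn(-c2cc(F)cc(F)c2)c2cc(F)ccc12`: > 40000 nM (a limit)

Compound 3 has no number, only the limit > 40000 nM. The series shows (the limit of > 40000 nM in this assay, at which 2 of the 3 values shown sit).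

Compound 4 `C[C@H](Nc1ncnc2[nH]cnc12)c1nn(-c2ccncc2)c2cc(F)ccc12` carries pyridin-4-yl in place of 3,5-difluorophenyl on an aromatic nitrogen.

Among the measured compounds shown here, two measured steps bear on this change, both at that nitrogen: an at least 2.9-fold lower number from compound 1 to compound 2 (0.47 log units; beyond the scatter) and an at least 2.9-fold higher number from compound 2 to compound 3 (0.47 log units; beyond the scatter). Only the 4-cyanophenyl group of compound 2 gave a number.

A modest move to a lower number is therefore expected, an at least 1.6-fold lower number from compound 3 to compound 4 (0.20 log units; that floor lies within the scatter), though another reading at the limit remains possible. For compound 4 the estimated value is 25000 nM, with an expected range of 10000 nM to 60000 nM.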

Compound 4, half-maximal inhibitory concentration: 21400 nM
The estimate for compound 4 lay 1.2-fold (0.07 log units) above the measured number; the measured number falls inside the stated range.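

In this assay, pyridin-4-yl joins 4-cyanophenyl as a second group at this aromatic nitrogen to give a number rather than a limit, and the two do not separate: a 1.6-fold higher number from compound 2 to compound 4 (0.20 log units; within the scatter). Going by these compounds, the steps from the two fluorinated compounds are floors only, an at least 1.8-fold lower number from compound 3 to compound 4 (0.27 log units; that floor lies within the scatter) and an at least 1.8-fold lower number from compound 1 to compound 4 (0.27 log units; that floor lies within the scatter), so their true size stays unknown: the limit of > 40000 nM in this assay, at which 2 of the 4 values shown sit. The compounds shown leave open whether an amine or a carboxylic acid on the ring at this nitrogen would give a clearly lower number than compound 2 and compound 4.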